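The source may hold more compounds than are shown below. What is called first, only, known or untested is meant among the compounds shown, and "the series" means these compounds.

Within the data shown here, in a functional assay on K-562R cells (Homo sapiens) for cytotoxicity, read by XTT assay, with a stated time of 24 h (a higher number here means a weaker inhibitor, a lower number a stronger inhibitor), compound 3 `COc1ccc(C(=O)Nc2ccc(C)c(Nc3nccc(-c4cccnc4)n3)c2)c(OCCCCn2ccnc2)c1` gives 46600 nM, the highest of the three numbers so far. Compound 1 `COc1cc(C(=O)Nc2ccc(C)c(Nc3nccc(-c4cccnc4)n3)c2)ccc1OCCCCn1ccnc1` gives 27100 nM, which lies within the usual scatter of compound 3, while compound 2 `COc1ccc(C(=O)Nc2ccc(C)c(Nc3nccc(-c4cccnc4)n3)c2)cc1OCCCCn1ccnc1` gives 18700 nM, a gap that goes beyond the scatter. Compound 4 `Cc1ccc(NC(=O)c2ccc(Br)cc2OCCCCn2ccnc2)cc1Nc1nccc(-c2cccnc2)n1` has not yet been measured in this assay. It differs from compound 3 in one place: bromo in place of methoxy on an aromatic carbon. The bromo sits on an aromatic carbon of a six-membered aromatic ring of carbon only, meta to the 4-(1H-imidazol-1-yl)butoxy group and para to a large group. Among the measured compounds shown here, no measured pair shows this exchange, so nothing here points to a direction. The step is expected to stay within the scatter, a 1.2-fold lower number from compound 3 to compound 4 (0.09 log units; within the scatter). Compound 4 is therefore estimated at 38000 nM, with a range from 13000 nM to 110000 nM.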

Compound 4, half-maximal inhibitory concentration: 44600 nM
For compound 4 the middle estimate is 1.2-fold (0.07 log units) below the measured one; the range from low to high includes it.
By their numbers in this assay, from the lowest: compounds 2, 1, 4 and 3 (each within the scatter of the next, the first and the last beyond it).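

In this assay, among these compounds, bromo in place of methoxy on this aromatic carbon, meta to a 4-(1H-imidazol-1-yl)butoxy group and para to a large group, gives a first reading for this change (a 1.0-fold lower number from compound 3 to compound 4 (0.02 log units; within the scatter)). At this position, then, losing the methoxy with its hydrogen-bond acceptor and adding a bromine atom leaves the number essentially unchanged. Nothing available explains this result. From the compounds shown here alone, whether an amine or a carboxylic acid at this position would shift the number remains open. So does whether a longer chain in place of the 4-(1H-imidazol-1-yl)butoxy group would keep bromo and methoxy this close.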